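The compounds below may be only part of what the source reports. "The series", "measured", "known", "first", "only" and "open" are said of these compounds alone.

Measured compounds in an assay on cells for inhibition of Amine oxidase [flavin-containing] A (Homo sapiens), read by fluorescence and Amplex Red, with a stated time of 15 min; on this read-out lower numbers stand for stronger inhibition and higher numbers for weaker inhibition:
compound 1 `Cc1cccc2cc(-c3ccccc3Br)oc12`: 100000 nM
compound 2 `Cc1ccc2oc(-c3cccc(Br)c3)cc2c1`: > 100000 nM (a limit of the assay, not a number)
compound 3 `Cc1cccc2cc(-c3cccc(Br)c3)oc12`: > 100000 nM (a limit of the assay, not a number)

Within the data shown here, compound 1 holds the only number in this assay. Compound 2 returns a limit only. Compound 3 likewise returns a limit only. The weak end of the series is fixed by the limit of > 100000 nM in this assay, at which 2 of the 3 values shown sit. Compound 1 therefore stands at the weak edge of what this assay resolves, with no second number to set it against.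

Compound 4 `Brc1ccccc1-c1cc2ccccc2o1` differs from compound 1 in one place: hydrogen in place of methyl on an aromatic carbon. The methyl leaves the aromatic carbon of the six-membered ring in the fused system, ortho to a fused ring and meta to a fused ring, and hydrogen takes its place. Among the measured compounds shown here, no measured pair follows a change of this kind, so the step has no precedent here.

Compound 1 sits at the weak end with 100000 nM, and the loss of a single methyl is expected to move this assay's read-out in neither direction beyond the scatter. Compound 4 is expected at 100000 nM, with a range from 30000 nM to 300000 nM. The expected step of no change at the digits printed from compound 1 to compound 4 (within the scatter) amounts to no change beyond the scatter, with a fair chance that only a limit is returned.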

Compound 4, half-maximal inhibitory concentration: 8120 nM
The estimate for compound 4 lay 12-fold (1.09 log units) above the measured number; measured number below the stated range.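

In this assay, among these compounds, hydrogen in place of methyl on this aromatic carbon gives a 12-fold lower number from compound 1 to compound 4 (1.09 log units; beyond the scatter), the only step that can be read. This position of the six-membered ring in the fused system is therefore not silent, and within this pair the methyl goes with the higher number, that is, the weaker inhibition. Compound 2 and compound 3 each return a limit and not a number, so no second step stands beside this one: the limit of > 100000 nM in this assay, at which 2 of the 4 values shown sit.

Going by these compounds, it remains open whether another group on this aromatic carbon, such as a methoxy, an amine or a carboxylic acid, would keep the lower number of compound 4. On these data alone, it also remains open whether the same change gives a step of similar size on any compound other than compound 1.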